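A few compounds are considered here, and "the series" means these few. Any claim that something is new, unique, unknown or untested is made for them only; others in the source may bear on it.

Measured so far:
compound 1 `Cn1c(=O)c2c(nc(CSc3cccc(F)c3)n2C)n(C)c1=O` gives 50100 nM in an in vitro assay on cells for inhibition of Amine oxidase [flavin-containing] A (Homo sapiens), read by fluorescence and spectrophotometry, with a stated time of 20 min; on this read-out lower numbers stand for stronger inhibition and higher numbers for weaker inhibition;
compound 2 `COc1cccc(SCc2nc3c(c(=O)n(C)c(=O)n3C)n2C)c1` gives 41300 nM in this assay.

Compound 1 has the highest number of the two, and its nearest neighbour is compound 2: a 1.2-fold lower number from compound 1 to compound 2 (0.08 log units; within the scatter). Compound 3 `Cn1c(=O)c2c(nc(CSc3cccc(Br)c3)n2C)n(C)c1=O` differs from compound 1 by bromo in place of fluoro on an aromatic carbon. Among the compounds with values here, the only measured step on the same aromatic carbon, a 1.2-fold lower number from compound 1 to compound 2 (0.08 log units; within the scatter), stayed within the scatter, so no step beyond the scatter is expected in this assay from compound 1 to compound 3. Compound 3 is therefore estimated at 45000 nM, within 15000 nM to 140000 nM, which means an expected step of a 1.1-fold lower number from compound 1 to compound 3 (0.05 log units; within the scatter).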

Compound 3, half-maximal inhibitory concentration: 23800 nM
Compound 3: the middle estimate sits 1.9-fold (0.28 log units) above what was measured; measured number inside the range.
By their numbers in this assay, from the lowest: compounds 3, 2 and 1 (each within the scatter of the next, the first and the last beyond it).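

Swapping the group on this aromatic carbon can shift the number beyond the scatter after all: a 2.1-fold lower number from compound 1 to compound 3 (0.32 log units; beyond the scatter) is the first such step here, though a modest one. Bromo and methoxy, by contrast, remain within the scatter of each other, a 1.7-fold lower number from compound 2 to compound 3 (0.24 log units; within the scatter), so bromo is set apart from fluoro only. Nothing measured here gives a reason for this. As far as these compounds go, whether chloro or an amine on the same aromatic carbon would match bromo remains open. So does whether a larger group there, such as a longer chain, would lower the number further.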